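The source may report more compounds than this note shows. Statements on the series, on what has been measured and on what is new or still open speak of the compounds shown alone.

Measured so far, in an assay on COS-1 cells for displacement of a labelled ligand from sodium-dependent dopamine transporter (Homo sapiens); on this read-out lower numbers stand for stronger inhibition and higher numbers for weaker inhibition:
compound 1 `CCOC(=O)C1=C(c2ccc3ccccc3c2)CCNC1` gives 79 nM
compound 2 `COC(=O)C1=C(c2ccc(C(C)(C)C)cc2)CCCC1` gives 605000 nM

Compound 2 stands at the higher of the two numbers shown, far above compound 1, a gap well beyond the scatter. Compound 1 sits in a clearly active range, whereas compound 2 shows hardly any measurable inhibition on this read-out. The two differ in more than one place, so nothing can be read from the pair as a single step.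

The next compound, compound 3 `COC(=O)C1=C(c2ccc(OC(F)(F)F)cc2)CCCC1`, departs from compound 2 by one change: trifluoromethoxy in place of tert-butyl on an aromatic carbon. Among the compounds with values here, no measured pair shows what such a change does in this assay. The only measured neighbour, compound 2 at 605000 nM, sits at the higher of the two numbers shown. The expected step is a 1.7-fold lower number from compound 2 to compound 3 (0.24 log units; within the scatter), a move expected to stay within or near the scatter, with a slight lean toward a lower number. Compound 3 is estimated at 350000 nM, with a range from 60000 nM to 2000000 nM. A limit rather than a number is quite possible for compound 3.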

Compound 3, inhibition constant: 1660000 nM
Compound 3: middle estimate off by 4.7-fold (0.68 log units), on the low side; low and high end bracket the measured number.
By their numbers in this assay, from the lowest: compound 1; then compound 2; then compound 3.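

In this assay, within the data shown here, trifluoromethoxy in place of tert-butyl on this aromatic carbon gives a 2.7-fold higher number from compound 2 to compound 3 (0.44 log units; beyond the scatter) and so provides the first single-place step, a modest one that lies beyond the scatter. The direction is upward: of the two groups compared at this position on the shared core, trifluoromethoxy stands at the higher number and tert-butyl at the lower, though both compounds remain in the very weak range of this read-out. Nothing at hand bears on the reason for this step.

Among these compounds, only this one exchange at the aromatic carbon can be read, so it remains open how a chlorine, an amine or a carboxylic acid in the same place would compare with tert-butyl and trifluoromethoxy. Also open, going by these compounds, is whether the same exchange would give a step of similar size and direction on the core of compound 1 at 79 nM, and the gap that separates compound 2 from compound 1 cannot yet be assigned to any single change.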